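Swapping the pyridyl arm of compound 2 for furanyl

The compounds below may be only part of what the source reports. "The series", "measured", "known", "first", "only" and "open" are said of these compounds alone.

Compound 2 `Clc1ccc(-c2cc(-c3ccsc3)nc(-c3ccccn3)c2)o1` gives 0% in an assay on isolated protein for inhibition of DNA topoisomerase 1 (Homo sapiens), tested at 100 uM (a lower number here means a weaker effect, a higher number a stronger effect of the compound at the concentration tested), and stands lowest of the three numbers measured: nearest is compound 3 `Clc1ccc(-c2cc(-c3ccco3)cc(-c3cccs3)n2)cc1` with 2.7%, within the scatter of compound 2, while compound 1 `Clc1ccc(-c2cc(-c3ccc(Cl)o3)cc(-c3cccs3)n2)cc1` with 38.9% lies beyond it. Within the data shown here, the one measured step, a number 36.2 percentage points lower from compound 1 to compound 3 (beyond the scatter), is large but concerns hydrogen in place of chloro on an aromatic carbon, not the change at hand. Compound 4 `Clc1ccc(-c2cc(-c3ccsc3)nc(-c3ccco3)c2)o1` differs from compound 2 by furan-2-yl in place of pyridin-2-yl on an aromatic carbon, next to the ring nitrogen. Among the measured compounds shown here, no measured step covers this exchange, so the expected step of a number 3 percentage points higher from compound 2 to compound 4 (within the scatter) is none beyond the scatter. Compound 4 is therefore estimated at 3% in this assay, with a range from 0% to 15%.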

Compound 4, a percentage reported as inhibition, at one concentration (the size of the read-out at that concentration, not a potency): 8.2%
Beside the measured number, compound 4's estimate is 5.2 percentage points below it; the measured number falls inside the stated range.
By their numbers in this assay, from the lowest: compounds 2, 3 and 4 (each within the scatter of the next); then compound 1.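

In this assay, among these compounds, furan-2-yl in place of pyridin-2-yl next to the ring nitrogen gives a number 8.2 percentage points higher from compound 2 to compound 4 (within the scatter) and is the first reading at this position. On this core, the change from a six-membered to a five-membered aromatic ring, and from nitrogen to oxygen as hetero atom, therefore leaves no difference that can be read. No measurement bearing on this result is available.

On these data alone, whether an amine, a carboxylic acid or a longer chain at this position would give a step beyond the scatter remains open. Also open, as far as these compounds go, is how the same exchange would read on the core of compound 1 , which gives 38.9% in this assay.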